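Halogen for dimethyl on the anilino ring of compound 2

The compounds below may be only part of what the source reports. "The series", "measured", "known", "first", "only" and "open" are said of these compounds alone.

Measured so far:
compound 1 `CCn1c(=O)/c(=C2\Sc3cc(F)ccc3N2C)s/c1=C\c1ccncc1Nc1ccccc1F` — 260 nM
compound 2 `CCn1c(=O)/c(=C2\Sc3ccccc3N2C)s/c1=C\c1ccncc1Nc1cc(C)ccc1C` — 2000 nM
compound 3 `c1ccc(Nc2nc(-c3nc4ccccc4s3)cs2)cc1` — 5500 nM

In a functional assay on PC-3 cells (Homo sapiens) for inhibition (a lower number here means a stronger inhibitor, a higher number a weaker inhibitor), compound 2 sits second highest of the three numbers. Its nearest neighbour is compound 3, whose number is higher; the gap lies beyond the scatter. Compound 1 is the furthest, with a much lower number, again beyond the scatter. Among the compounds with values here, no pair differing in one place has been measured, so no directly comparable step is at hand.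

Compound 4 `CCn1c(=O)/c(=C2\Sc3ccccc3N2C)s/c1=C\c1ccncc1Nc1ccccc1Cl` is the not yet measured analogue; the change is 2-chlorophenyl in place of 2,5-dimethylphenyl on a nitrogen on an aromatic ring. Compound 1, which also carries a halogen on its anilino ring, gives 260 nM, so a move toward lower numbers is expected; the step of a 3.1-fold lower number from compound 2 to compound 4 (0.49 log units; beyond the scatter) is the expected size, though with the gap to compound 1 also depending on the shared core, the expectation is held with caution. For compound 4 the expected value is 650 nM, within 200 nM to 2000 nM.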

Compound 4, half-maximal inhibitory concentration: 780 nM
Compound 4: middle estimate off by 1.2-fold (0.08 log units), on the low side, and the stated range covers the measured number.
By their numbers in this assay, from the lowest: compound 1; then compound 4; then compound 2; then compound 3.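

In this assay, 2-chlorophenyl in place of 2,5-dimethylphenyl on a nitrogen on an aromatic ring gives a 2.6-fold lower number from compound 2 to compound 4 (0.41 log units; beyond the scatter). Within the data shown here, this is the first comparison that isolates this position, and it shows that the group here alone moves the number beyond the scatter, with the shared core unchanged. No measurement available here bears on the reason for the step.

The compounds shown leave open whether the lower number follows the chlorine or the loss of the methyl groups. Also open, on these data alone, is how an unsubstituted phenyl, or a phenyl carrying an amine or a carboxylic acid, would behave here.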